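Changing the aryl group on a shared core

The source may hold more compounds than are shown below. What is called first, only, known or untested is meant among the compounds shown, and "the series" means these compounds.

Of the compounds shown here, three built on one shared core have been tested in a functional assay on MDA-MB-231 cells (Homo sapiens) for inhibition, read by sulforhodamine B assay, with a stated time of 48 h, tested at 10 uM; a lower number here means less inhibition, a higher number more inhibition at the concentration tested (going by the name of the read-out). Compound 1 `c1ccc2c(-c3cn4ccnc4c(-c4ccc5ncn(C6CCCCC6)c5c4)n3)cccc2c1` gives 20.8%. Compound 2 `c1cn2cc(-c3ccsc3)nc(-c3ccc4ncn(C5CCCCC5)c4c3)c2n1` gives 1.35%, and compound 3 `CC(=O)c1ccc(-c2cn3ccnc3c(-c3ccc4ncn(C5CCCCC5)c4c3)n2)cc1` gives 7.65%. Compound 3 thus stands second highest of the three numbers: its nearest neighbour is compound 2, and the gap between them lies within the scatter, while compound 1 lies furthest from it, beyond the scatter. The two steps away from compound 1 are both beyond the scatter: a number 19.5 percentage points lower from compound 1 to compound 2 (beyond the scatter) and a number 13.2 percentage points lower from compound 1 to compound 3 (beyond the scatter). The step between the two lower compounds, a number 6.3 percentage points higher from compound 2 to compound 3 (within the scatter), stays within the scatter.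

Compound 4 `COc1ccccc1-c1cn2ccnc2c(-c2ccc3ncn(C4CCCCC4)c3c2)n1` is the next compound, and it differs from compound 3 in one place: 2-methoxyphenyl in place of 4-acetylphenyl on an aromatic carbon. Among the measured compounds shown here, the steps that bear on this change are the ones in which the group at the same aromatic carbon was exchanged, namely a number 13.2 percentage points lower from compound 1 to compound 3 (beyond the scatter) and a number 6.3 percentage points higher from compound 2 to compound 3 (within the scatter). Both were modest at most, and only the exchange involving naphthalen-1-yl went beyond the scatter. Exchanging one substituted phenyl for another is therefore expected to move the number little, if at all beyond the scatter. For compound 4 the estimated value in this assay is 11%, within a range from 1% to 26%. This estimate amounts to an expected step of a number 3.4 percentage points higher from compound 3 to compound 4 (within the scatter).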

Compound 4, a percentage reported as inhibition, at one concentration (the size of the read-out at that concentration, not a potency): 15.9%
Estimate against measurement, compound 4: 4.9 percentage points below; low and high end bracket the measured number.
By their numbers in this assay, from the lowest: compounds 2, 3, 4 and 1 (each within the scatter of the next, the first and the last beyond it).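

In this assay, a group with one six-membered aromatic ring at this carbon now cannot be told apart from naphthalen-1-yl (a number 4.9 percentage points lower from compound 1 to compound 4 (within the scatter)), so among these compounds the larger naphthalen-1-yl is not required to reach that level of inhibition. The result also shows that exchanging one substituted phenyl for another need not leave the same relation to thiophen-3-yl: 2-methoxyphenyl stands clear of thiophen-3-yl (a number 14.6 percentage points higher from compound 2 to compound 4 (beyond the scatter)), whereas 4-acetylphenyl did not, even though the two substituted phenyl groups themselves remain within the scatter of each other (a number 8.3 percentage points higher from compound 3 to compound 4 (within the scatter)). The four compounds therefore form an overlapping chain rather than separate tiers, and nothing available explains why these groups differ.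

From the compounds shown here alone, all four groups are aromatic rings joined directly to this carbon, so the effect of an amine, a carboxylic acid or a longer alkyl chain at this place remains open. Also open, going by these compounds, is whether 4-methoxyphenyl would match 2-methoxyphenyl, and whether any of these readings at a single concentration would hold as a difference in potency.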